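Morpholine for thiomorpholine on a fluoropyridine thiosemicarbazide

The source may report more compounds than this note shows. Statements on the series, on what has been measured and on what is new or still open speak of the compounds shown alone.

Measured compounds:
compound 1 `N/C(=N\NC(=S)N1CCOCC1)c1ccccn1` gives 4800 nM
compound 2 `N/C(=N\NC(=S)N1CCCC1)c1ccc(F)cn1` gives 1000 nM
compound 3 `N/C(=N\NC(=S)N1CCSCC1)c1ccc(F)cn1` gives 1200 nM

In a functional assay on A-431 cells (Homo sapiens) for cytotoxicity, read by MTT assay, with a stated time of 72 h (a higher number here means a weaker inhibitor, a lower number a stronger inhibitor), compound 3 gives 1200 nM, the second highest of the three numbers; compound 2 sits nearest, and compound 1 furthest with a higher number. Compound 4 `N/C(=N\NC(=S)N1CCOCC1)c1ccc(F)cn1` has not been measured. It differs from compound 3 by morpholin-4-yl in place of thiomorpholin-4-yl on a thiocarbonyl carbon. For the measured compounds named here, no measured step exchanges thiomorpholin-4-yl for morpholin-4-yl directly. Going by the values given here, the one step that changes the ring on the thiocarbonyl carbon, a 1.2-fold higher number from compound 2 to compound 3 (0.08 log units; within the scatter), was small. Among the compounds with values here, compound 1, which carries morpholin-4-yl but no fluorine, shows a higher number than compound 3, though the two differ in two places and no single step connects them. A modest rise in this assay is therefore expected, a 1.7-fold higher number from compound 3 to compound 4 (0.22 log units; within the scatter), with wide uncertainty. Compound 4 is estimated at 2000 nM, within a range of 800 nM to 5000 nM.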

Compound 4, half-maximal inhibitory concentration: 4000 nM
Estimate against measurement, compound 4: 2.0-fold (0.30 log units) below; measured number inside the range.
By their numbers in this assay, from the lowest: compounds 2 and 3 (each within the scatter of the next); then compounds 4 and 1 (each within the scatter of the next).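

In this assay, for the compounds shown here, the ring on the thiocarbonyl carbon now makes a difference beyond the scatter, which the one earlier ring step did not show: morpholin-4-yl in place of thiomorpholin-4-yl gives a 3.3-fold higher number from compound 3 to compound 4 (0.52 log units; beyond the scatter), and morpholin-4-yl in place of pyrrolidin-1-yl gives a 4.0-fold higher number from compound 2 to compound 4 (0.60 log units; beyond the scatter). With the fluoro group held constant, this position therefore sets morpholin-4-yl apart from the other two rings, which remain within the scatter of each other. The fluoro group, by contrast, shows no effect beyond the scatter with morpholin-4-yl in place, with fluoro in place of hydrogen on an aromatic carbon giving a 1.2-fold lower number from compound 1 to compound 4 (0.08 log units; within the scatter).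

As far as these compounds go, a piperazine ring or an open-chain dimethylamino group on the thiocarbonyl carbon remains open, as does whether removing the fluoro group would matter with pyrrolidin-1-yl or thiomorpholin-4-yl. Nothing available here accounts for the separation of morpholin-4-yl from the other two rings.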